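This account rests on a few compounds, and the source may have more. Where it says the series, first, only, none or still open, it means among the compounds named here.

- compound 1 `N#CCCCn1c(Cn2c(=O)n(-c3ncco3)c3ccncc32)cc2cc(Cl)ccc21` gives > 50000 nM as a limit
- compound 2 `CS(=O)(=O)c1ccc(-n2c(=O)n(Cc3cc4cc(Cl)ccc4n3CCCC#N)c3cnccc32)cc1` gives > 50000 nM as a limit

In an ADME assay on HeLa cells (Homo sapiens) for cytotoxicity, read by ATP content, with a stated time of 3 days (a lower number here means that less compound is tolerated, a higher number that more compound is tolerated), compound 2 stands at > 50000 nM as a limit, not a number. Compound 3 `N#CCCCn1c(Cn2c(=O)n(-c3ccc(C(=O)O)cc3)c3ccncc32)cc2cc(Cl)ccc21` differs from it by carboxy in place of methylsulfonyl on an aromatic carbon with carboxy in place of methylsulfonyl on an aromatic carbon, para to a large group. Among the compounds with values here, the only measured step, a step that the two limits leave unreadable from compound 1 to compound 2, has no readable size, and the sole other evidence is the limit of > 50000 nM in this assay, at which 2 of the 2 values shown sit, so little bears on this change. The estimated step is a number no higher from compound 2 to compound 3 (the limit leaves the size open), with no change beyond the scatter expected in either direction. Compound 3 is expected at 50000 nM, with an estimated range of 25000 nM to 100000 nM, most likely reported as a limit again.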

Compound 3, half-maximal cytotoxic concentration: > 50000 nM
Compound 3: no number, only a limit; the forecaster's own chance of this, stated with the estimate: 85%; the middle value lies on the limit itself.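

No step can be read among compound 1, compound 2 and compound 3 in this assay, since each result is only a limit: the limit of > 50000 nM in this assay, at which 3 of the 3 values shown sit.

On these data alone, whether 1,3-oxazol-2-yl, 4-(methylsulfonyl)phenyl or 4-carboxyphenyl makes any difference to cytotoxicity remains open.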